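A few compounds are considered here, and "the series" means these few. Any claim that something is new, unique, unknown or untested is made for them only; others in the source may bear on it.

Compound 2 `NS(=O)(=O)c1cccc(Nc2nc(NCc3ccccc3)c3ccccc3n2)c1` stands alongside compound 1 `c1ccc(CNc2nc(Nc3ccccc3)nc3ccccc23)cc1` on the numbers shown so far. In an ADME assay on A549 cells (Homo sapiens) for cytotoxicity, read by MTT assay, with a stated time of 72 h (on this read-out higher numbers stand for weaker inhibition and lower numbers for stronger inhibition), compound 2 gives 11200 nM. Compound 1 gives 12300 nM in this assay, and the step between them reads a 1.1-fold lower number from compound 1 to compound 2 (0.04 log units; within the scatter), so the two sit within the scatter of each other. Compound 3 `NS(=O)(=O)c1cccc(Nc2nc(NCc3cccs3)c3ccccc3n2)c1` differs from compound 2 by thiophen-2-yl in place of phenyl on a saturated chain carbon bound to a nitrogen on an aromatic ring. Going by the values given here, no measured step bears on this change; the only step seen swapped a hydrogen for a sulfamoyl group and stayed within the scatter. Compound 3 is therefore expected to give 11200 nM, with a range of 5600 nM to 22400 nM, an expected step of no change at the digits printed from compound 2 to compound 3 (within the scatter) meaning nothing beyond the scatter.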

Compound 3, half-maximal inhibitory concentration: 15000 nM
For compound 3 the middle estimate is 1.3-fold (0.13 log units) below the measured one; measured number inside the range.
By their numbers in this assay, from the lowest: compounds 2, 1 and 3 (each within the scatter of the next).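

Among the compounds shown, only this step touches the saturated chain carbon bound to a nitrogen on an aromatic ring: in this assay thiophen-2-yl in place of phenyl gives a 1.3-fold higher number from compound 2 to compound 3 (0.13 log units; within the scatter), within the scatter. The read-out therefore does not separate the two aromatic rings at this place, so the sulfur-containing five-membered ring serves here as well as phenyl. No measurement at hand accounts for this result.

Going by these compounds, it remains open whether an amine, a carboxylic acid or a longer chain at this place would move the number in this assay beyond the scatter.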